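The source may report more compounds than this note shows. Statements on the series, on what has been measured and on what is new or still open speak of the compounds shown alone.

Compound 2, with the structure `COc1cc2ncnc(Nc3ccc(F)cc3)c2cc1OCCCCC(=O)Nc1ccc(S(N)(=O)=O)cc1`, sits at the edge of what this study can report. In a functional assay on A549 cells (Homo sapiens) for antiproliferative activity, read by MTT assay, with a stated time of 72 h (on this read-out higher numbers stand for weaker inhibition and lower numbers for stronger inhibition), compound 2 gives > 40000 nM, which is a limit of the assay and not a number, the point described by the limit of > 40000 nM in this assay, at which 1 of the 2 values shown sits. Its companion compound 1, `C#Cc1cccc(Nc2ncnc3cc(OC)c(OCCCCC(=O)Nc4ccc(S(N)(=O)=O)cc4)cc23)c1`, gives in this assay 7720 nM, and the change between them shows an at least 5.1-fold higher number from compound 1 to compound 2 (0.71 log units; beyond the scatter). The step now considered leads to compound 3, `COc1cc2ncnc(Nc3ccc(Br)cc3)c2cc1OCCCCC(=O)Nc1ccc(S(N)(=O)=O)cc1`, by bromo in place of fluoro on an aromatic carbon. Going by the values given here, no measured step in this set exchanges one halogen for another; the only measured step concerns the ethynyl substituent, so it does not bear directly on this exchange. Compound 3 is therefore expected to remain close to compound 2, with an at least 1.6-fold lower number from compound 2 to compound 3 (0.20 log units; that floor lies within the scatter) as a modest improvement at best. Compound 3 is estimated at 25000 nM, in the range 6000 nM to 60000 nM.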

Compound 3, half-maximal inhibitory concentration: > 40000 nM
Compound 3: no number, only a limit (the forecaster's own chance of this, stated with the estimate: 45%); middle value at least 1.6-fold (0.20 log units) away from the limit.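

Compound 3 gives > 40000 nM in this assay, again a limit of the assay and not a number, so the exchange of fluoro for bromo cannot be read as a step. What the result adds is that the weakening against the 3-ethynylphenyl group of compound 1 is not confined to the 4-fluorophenyl group, as the 4-bromophenyl group on the same nitrogen also shows an at least 5.1-fold higher number from compound 1 to compound 3 (0.71 log units; beyond the scatter). Any difference between the two halogens lies out of reach of this read-out, with both compounds ending at the same limit: the limit of > 40000 nM in this assay, at which 2 of the 3 values shown sit.

The compounds shown leave open whether the kind of substituent or its place on the ring matters more, which a 3-bromophenyl or a 4-ethynylphenyl group would separate. They also leave open how a 4-aminophenyl group would read at this nitrogen.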